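Dichlorophenyl amide and the maximal response of a sulfonamide series

The compounds below may be only part of what the source reports. "The series", "measured", "known", "first", "only" and "open" are said of these compounds alone.

Compound 2 `Cc1cc(Br)ccc1C(=O)Nc1ccc(S(=O)(=O)Nc2ccccc2)cc1`: 103%
Compound 1 `O=C(Nc1cccc(S(=O)(=O)Nc2ccccc2)c1)c1ccc(Cl)cc1Cl`: "not determined" (no result reported)

In a functional assay on HEK293 cells for agonist activity at probable G-protein coupled receptor 27 (Homo sapiens), read by a luciferase reporter and beta-arrestin recruitment, with a stated time of 10 min (a higher number here means a larger maximal response, a lower number a smaller maximal response), compound 2 reaches 103%, a full response against the reference. Compound 1 carries no number in this assay; its entry is "not determined" (no result reported). For the measured compounds named here, compound 2 therefore stands alone as the only measured point, and no step between measured compounds can be drawn.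

Compound 3 `O=C(Nc1ccc(S(=O)(=O)Nc2ccccc2)cc1)c1ccc(Cl)cc1Cl` is the compound still to be measured. It differs from compound 2 in one place: 2,4-dichlorophenyl in place of 4-bromo-2-methylphenyl on a carbonyl carbon. The change leaves the sulfonamide and the amide link untouched and swaps one substituted phenyl on the carbonyl carbon for another of the same size.

Going by the values given here, with a single measured value and no steps to lean on, the expectation is that the step of a number 8 percentage points lower from compound 2 to compound 3 (within the scatter) stays within the usual scatter or dips only slightly. Compound 3 is estimated to give 95% in this assay, with a range from 65% to 115%.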

Compound 3, largest response reached (Emax), in percent of the reference or control that the assay uses: 100%
The estimate for compound 3 lay 5 percentage points below the measured number; low and high end bracket the measured number.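

In this assay, for the compounds shown here, exchanging 4-bromo-2-methylphenyl for 2,4-dichlorophenyl on a carbonyl carbon gives a number 3 percentage points lower from compound 2 to compound 3 (within the scatter), the first reading at this place, which the lone earlier number could not supply. Both groups are single aromatic carbon rings with the same heavy-atom count, no hydrogen-bond donors or acceptors and no net charge, and the read-out does not tell them apart, so for this pair the change of substituents leaves the maximal response where it was. Nothing measured here bears on why the response holds across this exchange.

Going by these compounds, compound 1, which carries the same 2,4-dichlorophenyl group on its carbonyl carbon, remains at "not determined" (no result reported) in this assay, so it adds no comparison with compound 3 and the effect of the difference between their cores stays unknown. Also open, on these data alone, is whether the response would survive at this place with a group of another kind, such as an unsubstituted phenyl, a phenyl bearing an amine or a carboxylic acid, or a longer alkyl chain in place of the ring.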